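This account rests on a few compounds, and the source may have more. Where it says the series, first, only, none or still open, it means among the compounds named here.

Working notes on the hydroxamate series in an assay on Sf9 cells for inhibition of histone deacetylase 11 (Homo sapiens), read by fluorescence, tested at 0.5 uM; on this read-out higher numbers stand for more inhibition at the one concentration tested (going by the name of the read-out) and lower numbers for less inhibition.

Compound 3 `O=C(NO)c1cccc(-c2cn([C@H]3C[C@H](CO)N(Cc4ccccc4)C3)nn2)c1` carries a benzyl group on the ring nitrogen; in this assay compound 3 gives < 10%, which is a limit of the assay and not a number. Compound 1 `O=C(NO)c1cccc(-c2cn([C@H]3C[C@H](CO)N(CCCc4ccccc4)C3)nn2)c1` has the same core but with the change (phenethyl in place of phenyl on a saturated chain carbon bound to an amine nitrogen in a ring). In this assay compound 1 gives < 10%, again a limit of the assay and not a number. The step that the two limits leave unreadable from compound 3 to compound 1 is therefore not readable, because of the limit of < 10% in this assay, at which 2 of the 3 values shown sit.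

Compound 2 `O=C(/C=C/c1cn([C@H]2C[C@H](CO)N(Cc3ccccc3)C2)nn1)NO` belongs to a second core; the difference between the two cores is not broken down here. In this assay, for the measured compounds named here, compound 2 gives 20%, the only plain number in the set so far.

Compound 4 `O=C(/C=C/c1cn([C@H]2C[C@H](CO)N(CCCc3ccccc3)C2)nn1)NO` is not yet measured. It relates to compound 2 by phenethyl in place of phenyl on a saturated chain carbon bound to an amine nitrogen in a ring, the same kind of change as that from compound 3 to compound 1, made at the same place. That earlier step gives no readable size, so no direction can be carried over from it. The expectation for compound 4 therefore rests on compound 2 alone, whose value of 20% is a plain number and a small one, and a step of about a number 3 percentage points lower from compound 2 to compound 4 (within the scatter) is expected. Compound 4 is estimated at 17%, with a range from 5% to 32%, and a fair chance that only a limit is reported.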

Compound 4, a percentage reported as inhibition, at one concentration (the size of the read-out at that concentration, not a potency): 16%
Beside the measured number, compound 4's estimate is 1 percentage points above it; the range from low to high includes it.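

In this assay, benzyl to 3-phenylpropyl on the core of compound 2 reads as a number 4 percentage points lower from compound 2 to compound 4 (within the scatter), so on this core the change shows no effect that can be told from the scatter. On the core of compound 3 the same change gives no step to set against this one, and no statement about carrying it from one core to the other can be made, since both ends of that step are limits of the assay and not numbers: the limit of < 10% in this assay, at which 2 of the 4 values shown sit.

With the 3-phenylpropyl group held fixed, 2-(hydroxycarbamoyl)ethenyl in place of 3-(hydroxycarbamoyl)phenyl reads as a number at least 6 percentage points higher from compound 1 to compound 4 (that floor lies within the scatter), and this floor does not separate the two cores either, so the notes support neither a shared effect of the change nor a different one on each core.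

Still open, on these data alone, is whether any group at this place moves the read-out beyond the scatter on either core, for instance a longer chain than 3-phenylpropyl, or an amine or a carboxylic acid in place of the phenyl group. Also open, as far as these compounds go, is how the two cores compare at concentrations other than the single one tested, where the compounds now at a limit might give plain numbers.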